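Methyl on the Fused Ring of Two Hydroxy Cores

The source may report more compounds than this note shows. Statements on the series, on what has been measured and on what is new or still open speak of the compounds shown alone.

Compound 1 `COc1ccc(-c2cc(O)c3cccnc3n2)cc1` and compound 2 `COc1ccccc1-c1cc(O)c2cccnc2n1` are built from the same atoms joined differently; the difference between the two cores is not broken down here. In a functional assay on 786-0 cells (Homo sapiens) (on this read-out lower numbers stand for stronger inhibition of growth and higher numbers for weaker inhibition of growth), compound 1 gives 56200 nM, while compound 2 gives 36300 nM, the lower of the two numbers yet within the scatter of compound 1. Compound 3 `COc1ccc(-c2cc(O)c3ccc(C)nc3n2)cc1` carries methyl in place of hydrogen on an aromatic carbon. For compound 3 the assay reports only (the limit of > 100000 nM in this assay, at which 1 of the 3 values shown sits), so its value of > 100000 nM is a limit rather than a number. The step of an at least 1.7-fold higher number from compound 1 to compound 3 (0.25 log units; that floor lies within the scatter) thus has only a floor. Compound 4 `COc1ccccc1-c1cc(O)c2cc(C)cnc2n1` bears the same kind of change on compound 2, (methyl in place of hydrogen on an aromatic carbon), the methyl standing two atoms from the ring nitrogen instead of next to it. Compound 4 is expected to give a weaker number, a step of a 1.9-fold higher number from compound 2 to compound 4 (0.29 log units; within the scatter), resting on the floor set by an at least 1.7-fold higher number from compound 1 to compound 3 (0.25 log units; that floor lies within the scatter). The estimate for compound 4 is 70000 nM, expected to fall between 30000 nM and 160000 nM.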

Compound 4, concentration for 50% growth inhibition: 41700 nM
The estimate for compound 4 lay 1.7-fold (0.22 log units) above the measured number, within the range that was stated.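

In this assay methyl in place of hydrogen on the core of compound 2 gives a 1.1-fold higher number from compound 2 to compound 4 (0.06 log units; within the scatter) and leaves the two numbers indistinguishable. For compound 3 the value > 100000 nM is a limit and not a number. The pair of steps therefore shows neither that the change carries over from one core to the other nor that it fails to: the same change on two cores in this assay, an at least 1.7-fold higher number (0.25 log units; that floor lies within the scatter) from compound 1 to compound 3 and a 1.1-fold higher number (0.06 log units; within the scatter) from compound 2 to compound 4; the limit leaves it open whether they differ.

As far as these compounds go, whether an amine, a carboxylic acid or a longer chain on the fused ring would move the number stays open. So does how methyl two atoms from the ring nitrogen would read on the core of compound 1.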